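The compounds below may be only part of what the source reports. "The series", "measured", "known", "first", "only" and "open" are said of these compounds alone.

Compound 1, with the structure `CC1(C)[C@@H]2CC[C@@]1(CS(=O)(=O)N1CCN(c3cc(C(F)(F)F)ccn3)CC1)C(=O)C2`, is the starting point of this step. In a functional assay on CHO-K1 cells for antagonist activity at C-X-C chemokine receptor type 3 (Homo sapiens), read by FLIPR and calcium flux (on this read-out higher numbers stand for weaker inhibition and lower numbers for stronger inhibition), compound 1 gives 25100 nM, the highest number among the three compounds measured here, which on this read-out means the weakest inhibition. Compound 3, with the structure `CC1(C)[C@@H]2CC[C@@]1(CS(=O)(=O)N1CCCN(c3ccc(C(F)(F)F)cn3)CC1)C(=O)C2`, gives 6310 nM in this assay, and compound 2, with the structure `C[C@H]1CN(S(=O)(=O)C[C@]23CC[C@H](CC2=O)C3(C)C)CCN1c1ccc(C(F)(F)F)cn1`, gives 158 nM, both clearly lower than the number for compound 1 and both beyond the usual scatter. Among the measured compounds shown here, neither compound 3 nor compound 2 differs from compound 1 in only one place, so no single step between measured compounds can be read off.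

Compound 4, with the structure `CC1(C)[C@@H]2CC[C@@]1(CS(=O)(=O)N1CCN(c3ncc(Br)cn3)CC1)C(=O)C2`, is not yet measured. It keeps the core of compound 1 and changes one group on the amine nitrogen in a ring: 5-bromopyrimidin-2-yl in place of 4-(trifluoromethyl)pyridin-2-yl on an amine nitrogen in a ring. The measured compounds give no direct guide to this change, so the direction is uncertain. Compound 4 is estimated to give 6000 nM in this assay, within the range 1000 nM to 30000 nM, which would be a step of a 4.2-fold lower number from compound 1 to compound 4 (0.62 log units; beyond the scatter), expected to be modest and toward stronger inhibition.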

Compound 4, half-maximal inhibitory concentration: 631 nM
Compound 4: the middle estimate sits 9.5-fold (0.98 log units) above what was measured; measured number below the stated range.
By their numbers in this assay, from the lowest: compound 2; then compound 4; then compound 3; then compound 1.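

The swap of 4-(trifluoromethyl)pyridin-2-yl for 5-bromopyrimidin-2-yl on the amine nitrogen, with the core of compound 1 unchanged, gives in this assay a 40-fold lower number from compound 1 to compound 4 (1.60 log units; beyond the scatter), a large move toward stronger inhibition. This is the first change in one place among the compounds shown, and it reveals that the group at this position alone can strongly alter the read-out. It also shows that the trifluoromethyl group is not needed for inhibition at this level, although no measured property here explains the gain.

The step alters the ring and its substituent together, so the share of the second ring nitrogen and that of the bromine cannot be separated. A nitrile or a chlorine in place of the bromine on the pyrimidine ring remains an open comparison.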